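The source may report more compounds than this note shows. Statements on the series, on what has been measured and on what is new or still open speak of the compounds shown alone.

Working notes on the series. In a functional assay on HepG2 cells (Homo sapiens) for antiproliferative activity, read by MTT assay, with a stated time of 72 h (a higher number here means a weaker inhibitor, a lower number a stronger inhibitor), compound 1 `FC(F)(F)c1ccc(COc2cccc(Nc3ncnc4cc5c(cc34)OCCOCCO5)c2)cc1` gives > 100000 nM, which is a limit of the assay and not a number. For the measured compounds named here, compound 2 `O=[N+]([O-])c1ccc(COc2cccc(Nc3ncnc4cc5c(cc34)OCCOCCO5)c2)cc1` gives 65300 nM, the only number so far. Compound 3 `c1ccc(COc2cccc(Nc3ncnc4cc5c(cc34)OCCOCCO5)c2)cc1` differs from compound 2 by one change, hydrogen in place of nitro on an aromatic carbon, so that 4-nitrobenzyl becomes benzyl. Going by the values given here, the only measured step that bears on it, an at least 1.5-fold lower number from compound 1 to compound 2 (0.18 log units; that floor lies within the scatter), is a floor within the scatter, so no step beyond the scatter is expected in this assay and neither direction is favoured. A reading for compound 3 could also end at the limit: the limit of > 100000 nM in this assay, at which 1 of the 2 values shown sits. The expected change is a 1.1-fold higher number from compound 2 to compound 3 (0.03 log units; within the scatter), which stays inside the scatter. For compound 3 the estimated value is 70000 nM, with an expected range of 25000 nM to 100000 nM.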

Compound 3, half-maximal inhibitory concentration: > 100000 nM
Compound 3 ended at the assay's limit; the forecaster's own chance of this, stated with the estimate: 35%; middle value at least 1.4-fold (0.15 log units) from the limit.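

In this assay, for the compounds shown here, hydrogen in place of nitro on the aromatic carbon gives an at least 1.5-fold higher number from compound 2 to compound 3 (0.18 log units; that floor lies within the scatter), so even this change, the removal of any substituent at this position, yields no step that can be told from the scatter. Going by these compounds alone, the reading of compound 3 is a limit and not a number, and the plain benzyl group therefore gives no measurable value, leaving 4-nitrobenzyl as the only group here with a number, and the series now rests largely on one end of the range: the limit of > 100000 nM in this assay, at which 2 of the 3 values shown sit. The step between compound 1 and compound 3 cannot be read, since both ends are limits.

Open, on these data alone, is whether an amine or a carboxylic acid at this position would give a reading clearly inside the range of the assay. Also open, as far as these compounds go, is whether a longer chain in place of the benzyloxy link would do so.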